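Adding One Methyl to Compound 1

The source may report more compounds than this note shows. Statements on the series, on what has been measured and on what is new or still open speak of the compounds shown alone.

Within the data shown here, in a physicochemical assay for lipophilicity, using the shake flask method, in phosphate buffer, measured as octanol-water partition, with a stated time of 30 min, at pH 7.4 (on this read-out higher numbers stand for higher lipophilicity and lower numbers for lower lipophilicity), compound 1 `Cn1nccc1-c1cnc(NCc2c(F)ccc3c2CCO3)c2cn[nH]c(=O)c12` gives 2.6 and sits in the upper part of the three numbers so far. Compound 2 `Cc1ncccc1-c1cnc(NCc2c(F)ccc3c2CCO3)c2ncc(=O)[nH]c12` gives 2.8 which is within the scatter of compound 1. Compound 3 `CN(C)Cc1ccc2c(c1)CN(c1cnc(NCc3c(F)ccc4c3CCO4)n3cnnc13)C2=O` gives 1.6 which is clearly lower than compound 1.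

Compound 4 `Cc1cc(-c2cnc(NCc3c(F)ccc4c3CCO4)c3cn[nH]c(=O)c23)n(C)n1` has not been measured yet. It differs from compound 1 in one place only: methyl in place of hydrogen on an aromatic carbon with methyl in place of hydrogen on an aromatic carbon, so that 1-methyl-1H-pyrazol-5-yl becomes 1,3-dimethyl-1H-pyrazol-5-yl.

Among the measured compounds shown here, no two measured compounds differ in just one place, so nothing here shows this change directly. A small rise is expected in this assay with a number 0.30 log units higher from compound 1 to compound 4 (within the scatter) as the estimated step, which would reach no further than the edge of the usual scatter. For compound 4 the expected value is 2.9 with an estimated range from 2.5 to 3.3 in this measurement.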

Compound 4, distribution coefficient: 3
For compound 4 the middle estimate is 0.10 log units below the measured one; the measured number falls inside the stated range.
By their numbers in this assay, from the lowest: compound 3; then compounds 1, 2 and 4 (each within the scatter of the next, the first and the last beyond it).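

Among these compounds, the pair gives the first direct reading of this change: in this assay, turning 1-methyl-1H-pyrazol-5-yl into 1,3-dimethyl-1H-pyrazol-5-yl gives a number 0.40 log units higher from compound 1 to compound 4 (beyond the scatter), a modest step. On this aromatic carbon, two ring bonds from the ring atom that bears a large group, one added carbon is therefore enough to move the number past the usual scatter of repeated measurements. Nothing measured here explains why the number moves.

This single pair cannot show whether an ethyl group, a longer chain, an amine or a carboxylic acid at this position would move the number further or the opposite way. Nor can it show whether the same methyl change would give a similar step on another core, as compound 2 and compound 3 offer no such pair.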